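A few compounds are considered here, and "the series" means these few. Any claim that something is new, unique, unknown or untested is made for them only; others in the source may bear on it.

Measured so far in a functional assay on the whole organism for inhibition, with Lemna aequinoctialis as the target, tested at 10 ug/mL; a higher number here means more inhibition of growth at the concentration tested, a lower number less inhibition of growth

- compound 1 `CCCCCCNC(=S)N/N=C1\C(=O)Nc2ccc([N+](=O)[O-])cc21` gives 25%
- compound 2 `C=CCNC(=S)N/N=C1\C(=O)Nc2ccc([N+](=O)[O-])cc21` gives 25%
- compound 3 `Cc1ccc(NC(=S)N/N=C2\C(=O)Nc3ccc([N+](=O)[O-])cc32)cc1` gives 15%

Compound 2 stands level with compound 1, and compound 3 lies within the scatter of both. The change from compound 2 to compound 4 `O=C1Nc2ccc([N+](=O)[O-])cc2/C1=N/NC(=S)Nc1ccc(I)cc1` is 4-iodophenyl in place of allyl on an amide-type nitrogen or in words, 4-iodophenyl in place of allyl on an amide-type nitrogen.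

The closest measured step is a number 10 percentage points lower from compound 2 to compound 3 (within the scatter) with 4-methylphenyl entering on that same nitrogen. The step of a number 10 percentage points lower from compound 1 to compound 3 (within the scatter) is similar, and the step of no change at the digits printed from compound 1 to compound 2 (within the scatter) exchanges one chain for another. For the measured compounds named here, none of these goes beyond the scatter, and no measured compound carries iodine. The expected change in this assay is therefore small, a slight drop that stays within the scatter, with the estimated step of a number 7 percentage points lower from compound 2 to compound 4 (within the scatter) as the working figure. For compound 4 the estimated value is 18% with an expected range from 5% to 35% in this test.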

Compound 4, percent growth inhibition at one concentration: 5%
Compound 4: the middle estimate sits 13 percentage points above what was measured; the range from low to high includes it.
By their numbers in this assay, from the lowest: compounds 4, 3, 1 and 2 (each within the scatter of the next, the first and the last beyond it).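

In this assay, for the compounds shown here, swapping a chain on this amide-type nitrogen for 4-iodophenyl produces the first steps beyond the scatter: a number 20 percentage points lower from compound 2 to compound 4 (beyond the scatter), and a number 20 percentage points lower from compound 1 to compound 4 (beyond the scatter). Iodo in place of methyl on the aromatic carbon is a smaller matter, a number 10 percentage points lower from compound 3 to compound 4 (within the scatter), so that exchange alone cannot be told from noise. No measured evidence here explains the difference.

On these data alone, whether iodine or the aromatic ring counts more therefore stays open. So does what a plain phenyl, a 4-chlorophenyl or an amine-bearing chain would give on this nitrogen.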